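From butylamino to piperidin-1-yl

This account rests on a few compounds, and the source may have more. Where it says the series, first, only, none or still open, it means among the compounds named here.

Measured so far in a functional assay on the whole organism with Rattus norvegicus as the target; on this read-out lower numbers stand for an effect already at smaller amounts and higher numbers for an effect only at larger amounts of compound
Compound 1 `CCOC(=O)C(=O)Nc1cccc(N)c1C#N` gives 0.05 mg/kg
Compound 2 `CCCCNc1cccc(NC(=O)C(=O)OCC)c1C#N` gives 0.3 mg/kg

Compound 2 stands highest of the two. Compound 3 `CCOC(=O)C(=O)Nc1cccc(N2CCCCC2)c1C#N` has not yet been measured. It differs from compound 2 by piperidin-1-yl in place of butylamino on an aromatic carbon with piperidin-1-yl in place of butylamino on an aromatic carbon, ortho to a cyano group. Within the data shown here, only one measured step bears on this: a 6.0-fold higher number from compound 1 to compound 2 (0.78 log units; beyond the scatter) is modest and came with butyl in place of hydrogen on a nitrogen on an aromatic ring. A small further move toward a higher number in this assay is therefore expected, likely within the scatter. The estimated change is a 1.7-fold higher number from compound 2 to compound 3 (0.22 log units; within the scatter) and no larger shift is foreseen. Compound 3 is expected near 0.5 mg/kg with an estimated range from 0.1 mg/kg to 2.5 mg/kg in this read-out.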

Compound 3, dose for half-maximal effect: 2.2 mg/kg
Compound 3: the middle estimate sits 4.4-fold (0.64 log units) below what was measured; measured number inside the range.
By their numbers in this assay, from the lowest: compound 1; then compound 2; then compound 3.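

In this assay, the change at this aromatic carbon gives (a 7.3-fold higher number from compound 2 to compound 3 (0.87 log units; beyond the scatter)), so replacing butylamino with piperidin-1-yl moves the number up again, and the measured step from the amino compound is (a 44-fold higher number from compound 1 to compound 3 (1.64 log units; beyond the scatter)). Piperidin-1-yl is the first group here with 0 hydrogen-bond donors and the first with a ring, so the compounds cannot separate these two differences. No measurement of any property explains the shift.

From the compounds shown here alone, it remains open whether diethylamino, an open-chain group with no hydrogen on its nitrogen, would track butylamino or piperidin-1-yl. Pyrrolidin-1-yl would likewise show whether ring size matters at this position.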